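The source may hold more compounds than are shown below. What is called first, only, known or untested is meant among the compounds shown, and "the series" means these compounds.

Compound 1 `Oc1cc(C(F)(F)F)ccc1-c1nc(-c2ccccc2O)n(-c2ccc(F)cc2)n1` and compound 2 `Oc1cc(C(F)(F)F)ccc1-c1nc(-c2ccccc2O)n(-c2ccc(Br)cc2)n1` share one core and differ only in the halogen on the pendant ring. In a functional assay on PC-12 cells (Rattus norvegicus) for cytotoxicity, read by MTT assay, with stated times of 2 h and 24 h, tested at 5 uM (a lower number here means a weaker effect, a higher number a stronger effect of the compound at the concentration tested), compound 1 gives 86.7% and compound 2 gives 89.8%. Compound 2 holds the upper of the two numbers, but the step of a number 3.1 percentage points higher from compound 1 to compound 2 (within the scatter) is within the scatter, so the pair is not separated. Compound 3 `Oc1cc(C(F)(F)F)ccc1-c1nc(-c2ccccc2O)n(-c2ccc(I)cc2)n1` differs from compound 2 in one place: iodo in place of bromo on an aromatic carbon. Among the measured compounds shown here, the only step bearing on this change is the halogen exchange a number 3.1 percentage points higher from compound 1 to compound 2 (within the scatter); a further halogen exchange is therefore expected to give a number 0.2 percentage points higher from compound 2 to compound 3 (within the scatter), nothing beyond the scatter. The estimate for compound 3 is 90%, between 80% and 97%.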

Compound 3, a percentage reported as activity, at one concentration (the size of the read-out at that concentration, not a potency): 94.4%
For compound 3 the middle estimate is 4.4 percentage points below the measured one; measured number inside the range.
By their numbers in this assay, from the lowest: compounds 1, 2 and 3 (each within the scatter of the next).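

At this aromatic carbon, para to a large group, iodo in place of bromo gives a number 4.6 percentage points higher from compound 2 to compound 3 (within the scatter), and iodo in place of fluoro gives a number 7.7 percentage points higher from compound 1 to compound 3 (within the scatter). Iodo thus joins fluoro and bromo as a third halogen that this assay does not separate, even across the full span from fluoro to iodo. No evidence on the cause of these numbers is available.

Still open, on these data alone, is whether a group other than a halogen at this carbon, such as an amine, a carboxylic acid or a longer alkyl chain, would move the number beyond the scatter. The halogen series alone cannot show how far this position can be changed.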